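Removing a Methoxy Group from a Weak Amide

The source may hold more compounds than are shown below. What is called first, only, known or untested is meant among the compounds shown, and "the series" means these compounds.

Compound 1 `COc1ccc2c(=O)c(/C=C/C(=O)Nc3cccc(Cl)c3)coc2c1` gives 11900 nM in a functional assay on HeLa cells (Homo sapiens) for inhibition, read by MTT assay, with a stated time of 48 h; a higher number here means a weaker inhibitor, a lower number a stronger inhibitor. Compound 2 `COc1ccc(CNC(=O)/C=C/c2coc3cc(O)ccc3c2=O)cc1` reaches only a limit there, > 100000 nM, and so sits at the limit of > 100000 nM in this assay, at which 1 of the 2 values shown sits, its true strength unknown. Compound 3 `O=C(/C=C/c1coc2cc(O)ccc2c1=O)NCc1ccccc1` is not yet measured. Its difference from compound 2 is hydrogen in place of methoxy on an aromatic carbon. Within the data shown here, with no measured step to guide it, the change is expected to be small, within the usual scatter, in either direction: a number no higher from compound 2 to compound 3 (the limit leaves the size open). Compound 3 is therefore estimated at 100000 nM, ranging from 30000 nM to 300000 nM, quite possibly again only a limit.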

Compound 3, half-maximal inhibitory concentration: > 100000 nM
Compound 3: a limit, no number (the forecaster's own chance of this, stated with the estimate: 60%); the middle value sits exactly at the limit.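

Compound 2 and compound 3 both reach only a limit in this assay, and no step can be read between them. From the compounds shown here alone, whether 4-methoxyphenyl and phenyl differ in strength here, and by how much, stays open.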